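Working notes: 4-fluorophenyl to 4-methylphenyl

The compounds below may be only part of what the source reports. "The series", "measured", "known", "first", "only" and "open" are said of these compounds alone.

Measured in a functional assay on A549 cells (Homo sapiens) for antiproliferative activity, read by MTT assay; a lower number here means a stronger inhibitor, a higher number a weaker inhibitor:
- compound 1 `Cc1ccc2[nH]c(-c3c(-c4ccc(F)cc4)nc4sc(C)nn34)nc2c1`: 11700 nM
- compound 2 `Cc1nn2c(-c3nc4cc(Cl)ccc4[nH]3)c(-c3ccc(F)cc3)nc2s1`: 10200 nM

Not yet measured:
- compound 3 `Cc1ccc(-c2nc3sc(C)nn3c2-c2nc3cc(C)ccc3[nH]2)cc1`

Compound 1 has one measured neighbour, and the two numbers lie within the scatter of each other: a 1.1-fold lower number from compound 1 to compound 2 (0.06 log units; within the scatter). The change now in question leads to compound 3: methyl in place of fluoro on an aromatic carbon. Within the data shown here, the one measured step, chloro in place of methyl, lies at a different place in the molecule, and no measured step touches the 4-fluorophenyl group. It therefore offers only a weak guide, showing no more than that one single-atom swap left the number within the scatter. In this assay no step beyond the scatter is expected, in either direction. The estimated step is a 1.1-fold lower number from compound 1 to compound 3 (0.03 log units; within the scatter). Compound 3 is estimated at 11000 nM, with an expected range from 5000 nM to 24000 nM.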

Compound 3, half-maximal inhibitory concentration: 9800 nM
Compound 3: middle estimate off by 1.1-fold (0.05 log units), on the high side; low and high end bracket the measured number.
By their numbers in this assay, from the lowest: compounds 3, 2 and 1 (each within the scatter of the next).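

In this assay, among these compounds, 4-fluorophenyl to 4-methylphenyl gives a 1.2-fold lower number from compound 1 to compound 3 (0.08 log units; within the scatter), the first reading at this position, since the earlier step concerned a different place in the molecule. On this aromatic carbon, para to a large group, fluoro can therefore give way to methyl, one heavy atom for another, with the number staying within the scatter. No measurement at hand accounts for this outcome.

From the compounds shown here alone, both groups compared here are single heavy atoms, so whether an amine, a carboxylic acid or a longer chain at this position would move the number beyond the scatter remains open. Also open is whether 4-methylphenyl combined with the chloro group of compound 2 would stay within the scatter of these compounds.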